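This account rests on a few compounds, and the source may have more. Where it says the series, first, only, none or still open, it means among the compounds named here.

Three compounds share one core and differ only in the group on an amine nitrogen whose other neighbour is a carbon with a double bond to nitrogen. In a functional assay on MCF7 cells (Homo sapiens) for cytotoxicity, read by MTT assay, with a stated time of 48 h (on this read-out higher numbers stand for weaker inhibition and lower numbers for stronger inhibition), compound 1 `Cc1ccc(S(=O)(=O)/N=C(/CCNC2=CC(=O)c3ccccc3C2=O)Nc2ccccc2I)cc1` gives 15500 nM and compound 2 `Cc1ccc(S(=O)(=O)/N=C(/CCNC2=CC(=O)c3ccccc3C2=O)Nc2ccc(Cl)cc2Cl)cc1` gives 17000 nM. Compound 3 `Cc1ccc(S(=O)(=O)/N=C(/CCNC2=CC(=O)c3ccccc3C2=O)NC(C)C)cc1` gives 16500 nM in this assay, a number that sits within the scatter of both others; the steps of a 1.1-fold higher number from compound 1 to compound 3 (0.03 log units; within the scatter) and a 1.0-fold lower number from compound 2 to compound 3 (0.01 log units; within the scatter), like a 1.1-fold higher number from compound 1 to compound 2 (0.04 log units; within the scatter), are all too small to count as real differences. Compound 4 `Cc1ccc(S(=O)(=O)/N=C(/CCNC2=CC(=O)c3ccccc3C2=O)NC2CCCCC2)cc1` carries cyclohexyl in place of isopropyl on an amine nitrogen. Going by the values given here, no measured step tries this exact exchange, but the three steps already seen show that swapping an aryl group for isopropyl, or one aryl for another, on this nitrogen left the numbers unchanged within the scatter. The step of no change at the digits printed from compound 3 to compound 4 (within the scatter) is therefore expected to stay within the scatter as well, with no clear direction. Compound 4 is estimated at 16500 nM in this assay, with a range from 8000 nM to 34000 nM.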

Compound 4, half-maximal inhibitory concentration: 7580 nM
Estimate against measurement, compound 4: 2.2-fold (0.34 log units) above, and the stated range ends above it.
By their numbers in this assay, from the lowest: compound 4; then compounds 1, 3 and 2 (each within the scatter of the next).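

Until now the group on this amine nitrogen seemed to make no difference in this assay, yet cyclohexyl stands apart from all three earlier groups, with a 2.2-fold lower number from compound 3 to compound 4 (0.34 log units; beyond the scatter), a 2.2-fold lower number from compound 2 to compound 4 (0.35 log units; beyond the scatter) and a 2.0-fold lower number from compound 1 to compound 4 (0.31 log units; beyond the scatter). This position can therefore respond to a change, though only modestly, and the response appears with a six-membered non-aromatic ring of carbon only, not with isopropyl or either aryl group. Nothing at hand explains why this exchange moves the number when the earlier ones did not.

Whether the ring itself or simply the larger number of carbons goes with this step remains open: a straight hexyl chain and a cyclopentyl ring are not among the compounds shown. Also open, on these data alone, is whether a hydroxyl on the cyclohexyl ring, or a piperidine ring in its place, would keep the number at this level.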